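Urea Tail Swap in a Vasopressin V2 Receptor Agonist Series

This account rests on a few compounds, and the source may have more. Where it says the series, first, only, none or still open, it means among the compounds named here.

Compound 1 `Cc1cc(C(=O)N2CCCCc3ccccc32)ccc1CNC(=O)NCC(=O)O` gives 180 nM in a functional assay on HEK293 cells for agonist activity at Vasopressin V2 receptor (Homo sapiens), read by a luciferase reporter and cAMP accumulation; a lower number here means that less compound is needed, a higher number that more compound is needed for the effect.
Compound 2 `Cc1cc(C(=O)N2CCCCc3ccccc32)ccc1CNC(=O)NCC(=O)N(C)C` gives 58 nM in this assay.

Among the compounds with values here, compound 2 has the lower of the two numbers; the only measured step, a 3.1-fold lower number from compound 1 to compound 2 (0.49 log units; beyond the scatter), separates it from compound 1. Compound 3 `Cc1cc(C(=O)N2CCCCc3ccccc32)ccc1CNC(=O)N1CCC[C@H]1C(=O)OC(C)C` differs from compound 2 by 2-(isopropoxycarbonyl)pyrrolidin-1-yl in place of ((dimethylcarbamoyl)methyl)amino on a carbonyl carbon. Within the data shown here, that measured step concerns a different exchange on the same carbonyl carbon, so it offers only weak guidance, and no step of the new kind has been measured. The new change is expected to move the number little, if at all, in this assay: a 1.4-fold higher number from compound 2 to compound 3 (0.14 log units; within the scatter). Compound 3 is therefore estimated at 80 nM, within 20 nM to 320 nM.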

Compound 3, half-maximal effective concentration: 950 nM
Compound 3: the middle estimate sits 12-fold (1.07 log units) below what was measured, and the stated range ends below it.
By their numbers in this assay, from the lowest: compound 2; then compound 1; then compound 3.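

In this assay, this carbonyl carbon does not accept every tail equally: placing 2-(isopropoxycarbonyl)pyrrolidin-1-yl there in place of the dimethylamide tail gives a 16-fold higher number from compound 2 to compound 3 (1.21 log units; beyond the scatter) as the largest step seen so far. The carboxylic acid tail of the earlier compound also needs less compound for the effect, with the exchange from it giving a 5.3-fold higher number from compound 1 to compound 3 (0.72 log units; beyond the scatter) as its step. Nothing available here accounts for this loss.

The exchange changes the ring, the isopropyl ester and the stereocentre at once, so the compounds shown cannot separate their contributions. The same pyrrolidine ring carrying a carboxylic acid or a dimethylamide would help to tell them apart.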